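Swapping a bromophenyl for a nitrophenyl on a sulfonamide

The compounds below may be only part of what the source reports. "The series", "measured", "known", "first", "only" and "open" are said of these compounds alone.

Compound 1 `CCOC(=O)c1oc2ccc(NS(=O)(=O)c3ccc(Br)cc3)cc2c1C` gives 9310 nM in a functional assay on HCT-116 cells (Homo sapiens) for inhibition, read by MTT assay, with a stated time of 72 h; on this read-out lower numbers stand for stronger inhibition and higher numbers for weaker inhibition. Compound 2 `CCOC(=O)c1oc2ccc(N(Cc3ccccc3)S(=O)(=O)c3cccc(Br)c3)cc2c1C` differs from it in more than one place, so the two figures stand side by side without a counted step between them. In this assay compound 2 gives > 40000 nM, which is a limit of the assay rather than a number, as the limit of > 40000 nM in this assay, at which 1 of the 2 values shown sits, shows. Compound 3 `CCOC(=O)c1oc2ccc(N(Cc3ccccc3)S(=O)(=O)c3ccc([N+](=O)[O-])cc3)cc2c1C` has not yet been measured; it differs from compound 2 by 4-nitrophenyl in place of 3-bromophenyl on a sulfonyl sulfur. Going by the values given here, no measured pair follows this kind of change, so there is nothing to set its size or direction from, and the step of a number no higher from compound 2 to compound 3 (the limit leaves the size open) is expected to be small, staying within the scatter. Compound 3 is therefore expected to give 40000 nM in this assay, within a range from 10000 nM to 160000 nM, with a fair chance that only a limit is reported again.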

Compound 3, half-maximal inhibitory concentration: > 40000 nM
Compound 3: only a limit was reported (the forecaster's own chance of this, stated with the estimate: 60%); the middle value lies on the limit itself.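

No size can be read for the step from compound 2 to compound 3, because both compounds report only a limit: the limit of > 40000 nM in this assay, at which 2 of the 3 values shown sit.

The compounds shown leave open whether 3-bromophenyl or 4-nitrophenyl on a sulfonyl sulfur gives the stronger inhibition, since neither compound has a value that can be read as a number.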